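Cytotoxicity notes on the benzyloxy variation of the shared core

A few compounds are considered here, and "the series" means these few. Any claim that something is new, unique, unknown or untested is made for them only; others in the source may bear on it.

Compound 1 `CCOC(=O)c1cc(-c2cccc(OCc3cccc(F)c3)c2)on1` and compound 2 `CCOC(=O)c1cc(-c2cccc(OCc3cccc(Cl)c3)c2)on1` share one core and differ only by chloro in place of fluoro on an aromatic carbon. In an ADME assay on Vero cells (Chlorocebus sabaeus) for cytotoxicity, with a stated time of 72 h (a higher number here means a weaker inhibitor, a lower number a stronger inhibitor), compound 1 gives only a limit of the assay, > 128000 nM. In this assay compound 2 likewise gives only a limit, > 128000 nM. The step that the two limits leave unreadable from compound 1 to compound 2 therefore has no readable size, since both values sit at the limit of > 128000 nM in this assay, at which 2 of the 2 values shown sit. Compound 3 `CCOC(=O)c1cc(-c2cccc(OCc3ccccc3[N+](=O)[O-])c2)on1` differs from compound 2 by 2-nitrophenyl in place of 3-chlorophenyl on a saturated chain carbon bound to an oxygen on an aromatic ring. For the measured compounds named here, no measured step bears on this change, and the one step that exists is unreadable, so no direction can be taken from the measured pairs. Compound 3 is therefore expected to stay at the same limit, the step of a number no higher from compound 2 to compound 3 (the limit leaves the size open) being expected to show nothing beyond the scatter. The estimate for compound 3 in this assay is 128000 nM, with a range from 64000 nM to 256000 nM.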

Compound 3, half-maximal inhibitory concentration: > 128000 nM
Compound 3 ended at the assay's limit; the forecaster's own chance of this, stated with the estimate: 85%; the middle value sits exactly at the limit.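

In this assay, compound 1, compound 2 and compound 3 all stop at a limit, so no step among them can be read: the limit of > 128000 nM in this assay, at which 3 of the 3 values shown sit.

The compounds shown leave open whether 3-fluorophenyl, 3-chlorophenyl and 2-nitrophenyl differ at all in this assay.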